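One side group swapped on a shared core

This account rests on a few compounds, and the source may have more. Where it says the series, first, only, none or still open, it means among the compounds named here.

In an in vivo ADME assay on the whole organism (blood) for pharmacokinetics, with Rattus norvegicus as the target (on this read-out higher numbers stand for fast clearance and lower numbers for slow clearance), compound 1 `Cc1cc(C(=O)NCc2ccccn2)nn1Cc1cc(Cl)ccc1OCc1ccccc1` gives 68 mL/min/kg and compound 2 `Cc1cc(NC(=O)c2ccccc2)nn1Cc1cc(Cl)ccc1OCc1ccccc1` gives 50 mL/min/kg while compound 3 `Cc1cc(NC(=O)OC(C)(C)C)nn1Cc1cc(Cl)ccc1OCc1ccccc1` gives 42 mL/min/kg so all three lie within the usual scatter of one another. Compound 4 `Cc1cc(NC(=O)OCC(C)C)nn1Cc1cc(Cl)ccc1OCc1ccccc1` is still unmeasured and departs from compound 1 through one change ((isobutoxycarbonyl)amino in place of ((pyridin-2-yl)methyl)carbamoyl on an aromatic carbon) on the shared core. Going by the values given here, two measured steps bear on it: a 1.6-fold lower number from compound 1 to compound 3 (0.21 log units; within the scatter) and a 1.4-fold lower number from compound 1 to compound 2 (0.13 log units; within the scatter) are both within the scatter. Compound 3 is the closest guide, carrying (tert-butoxycarbonyl)amino where compound 4 carries (isobutoxycarbonyl)amino, and a 1.2-fold lower number from compound 2 to compound 3 (0.08 log units; within the scatter) also stays within the scatter. So a 1.5-fold lower number from compound 1 to compound 4 (0.18 log units; within the scatter) is the expected step in this assay and it is not expected to pass beyond the scatter. Compound 4 is estimated at 45 mL/min/kg with an expected range from 25 mL/min/kg to 75 mL/min/kg in this measurement.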

Compound 4, clearance: 124 mL/min/kg
Estimate against measurement, compound 4: 2.8-fold (0.44 log units) below, outside the stated range (above it).
By their numbers in this assay, from the lowest: compounds 3, 2, 1 and 4 (each within the scatter of the next, the first and the last beyond it).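

Swapping tert-butyl for isobutyl on the oxygen next to the carbonyl group gives a 3.0-fold higher number from compound 3 to compound 4 (0.47 log units; beyond the scatter), so in this assay a change confined to the end of this side group can move the number beyond the scatter. Isobutoxy in place of phenyl on the carbonyl carbon gives a 2.5-fold higher number from compound 2 to compound 4 (0.39 log units; beyond the scatter), whereas the replacement of the whole ((pyridin-2-yl)methyl)carbamoyl group gives a 1.8-fold higher number from compound 1 to compound 4 (0.26 log units; within the scatter). Nothing measured here explains these differences. The compounds shown leave open whether isobutyl is unusual among such ends: an n-butyl or cyclopropylmethyl group on the same oxygen would test this.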